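The source may hold more compounds than are shown below. What is called first, only, known or untested is meant among the compounds shown, and "the series" means these compounds.

Measured so far in a functional assay on MCF7 cells (Homo sapiens) for inhibition, read by MTT assay, with a stated time of 48 h; on this read-out lower numbers stand for stronger inhibition and higher numbers for weaker inhibition:
compound 1 `C=C1C(=O)N(c2ccccc2)N(c2ccccc2)C1c1ccccc1` — 4500 nM
compound 2 `C=C1CN(C)N(c2ccc(Br)cc2)C1=O` — 43800 nM
compound 3 `C=C1C(=O)N(c2ccccc2)N(C)C1c1ccccc1` — 84400 nM

Compound 3 gives the highest number of the three. For the measured compounds named here, its nearest neighbour is compound 2, whose value sits within the scatter of that of compound 3; its furthest is compound 1, from which the one single-point step runs: a 19-fold higher number from compound 1 to compound 3 (1.27 log units; beyond the scatter), a methyl in place of phenyl on an amine nitrogen in a ring. Compound 4 `C=C1CN(C)N(c2ccccc2)C1=O` differs from compound 3 by hydrogen in place of phenyl on a saturated ring carbon.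

Going by the values given here, no measured step matches this change. Among the compounds with values here, the only step on record, from compound 1 to compound 3, concerns the phenyl on the ring nitrogen, not the one on the saturated ring carbon, and cannot be carried over. What can be said is that compound 2, which lacks a substituent on that saturated ring carbon, gives a number within the scatter of compound 3. Compound 2 and compound 4 differ in more than one place, so their values are compared only loosely. On this basis the expected step in this assay, a 1.4-fold lower number from compound 3 to compound 4 (0.15 log units; within the scatter), is none beyond the scatter, with a wide range.

Compound 4 is therefore estimated at 60000 nM, between 20000 nM and 200000 nM.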

Compound 4, half-maximal inhibitory concentration: 56000 nM
Compound 4: the middle estimate sits 1.1-fold (0.03 log units) above what was measured; low and high end bracket the measured number.
By their numbers in this assay, from the lowest: compound 1; then compounds 2, 4 and 3 (each within the scatter of the next).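

In this assay hydrogen in place of phenyl on a saturated ring carbon gives a 1.5-fold lower number from compound 3 to compound 4 (0.18 log units; within the scatter) and thus stays within the scatter, so with methyl on the amine nitrogen of the ring, this phenyl shows no measurable contribution on this read-out. Hydrogen in place of bromo on an aromatic carbon gives a 1.3-fold higher number from compound 2 to compound 4 (0.11 log units; within the scatter) and also stays within the scatter, which leaves a 19-fold higher number from compound 1 to compound 3 (1.27 log units; beyond the scatter) as the only step of the series beyond it. Nothing at hand explains why the two new steps are small.

From the compounds shown here alone, compound 1 has no partner that differs from it only by hydrogen on the saturated ring carbon, so it remains open whether the phenyl there counts for as little when a phenyl, not a methyl, sits on the amine nitrogen of the ring. For the compounds shown here, also open is how this assay responds to an amine, a carboxylic acid or a longer chain on that saturated ring carbon, since phenyl and hydrogen are the only two groups compared there.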